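Swapping an Amino Linker for a Methylene Bridge

The source may hold more compounds than are shown below. What is called first, only, known or untested is meant among the compounds shown, and "the series" means these compounds.

compound 1 `CC(C)=CCc1cc(C(=O)Nc2cc3ccc(Oc4ccc(C(C)(C)C)cc4)c(C)c3oc2=O)ccc1O` in a functional assay on MCF7 cells (Homo sapiens) for antiproliferative activity; a higher number here means a weaker inhibitor, a lower number a stronger inhibitor: 20600 nM
compound 2 `COc1ccc(Nc2ccc3cc(NC(=O)c4ccc(O)c(CC=C(C)C)c4)c(=O)oc3c2C)cc1` in this assay: > 100000 nM

In this assay compound 2 reports only a limit, > 100000 nM, which is the limit of > 100000 nM in this assay, at which 1 of the 2 values shown sits. For the measured compounds named here, the one measured step, an at least 4.8-fold higher number from compound 1 to compound 2 (0.68 log units; beyond the scatter), changed the same aromatic carbon that now changes again. Compound 3, `COc1ccc(Cc2ccc3cc(NC(=O)c4ccc(O)c(CC=C(C)C)c4)c(=O)oc3c2C)cc1`, differs from compound 2 by 4-methoxybenzyl in place of (4-methoxyphenyl)amino on an aromatic carbon. That earlier step moved the number at least modestly, but compound 2 already stands at the limit, so compound 3 is expected to stay near it: the step is estimated as an at least 1.2-fold lower number from compound 2 to compound 3 (0.09 log units; that floor lies within the scatter), giving compound 3 an expected 80000 nM, with a range from 20000 nM to 300000 nM.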

Compound 3, half-maximal inhibitory concentration: 13300 nM
Compound 3: the middle estimate sits 6.0-fold (0.78 log units) above what was measured; measured number below the stated range.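

In this assay, the link to the 4-methoxyphenyl ring matters at this aromatic carbon: 4-methoxybenzyl in place of (4-methoxyphenyl)amino gives an at least 7.5-fold lower number from compound 2 to compound 3 (0.87 log units; beyond the scatter). That size is only a floor, as the value of compound 2 is a limit: the limit of > 100000 nM in this assay, at which 1 of the 3 values shown sits.

The other comparison, a 1.5-fold lower number from compound 1 to compound 3 (0.19 log units; within the scatter), means that 4-methoxybenzyl and 4-(tert-butyl)phenoxy cannot be told apart at this position. Still open, from the compounds shown here alone, is how 4-methoxyphenoxy or 4-(tert-butyl)benzyl would behave at this carbon, and so whether the oxygen link and the methylene link are interchangeable when the ring substituent is held constant.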